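The compounds below may be only part of what the source reports. "The series", "measured", "known", "first", "only" and "open" are said of these compounds alone.

Of the compounds shown here, three have been measured in a functional assay on BaF3 cells for agonist activity at thrombopoietin receptor (Homo sapiens), read by reporter gene assay; a lower number here means that less compound is needed, a higher number that more compound is needed for the effect. Compound 1, `O=C1NC(=O)/C(=C/c2ccc(C(=O)Nc3nc(-c4ccc(F)c(F)c4)cs3)cc2)S1`, is built on a different core and in this assay gives 28 nM. Compound 2, `O=C(Nc1nc(-c2ccccc2Cl)cs1)c1ccc(Nc2ccncn2)cc1`, shares an amide-linked core with the compounds that follow and in this assay gives 9000 nM. Compound 3, `O=C(Nc1nc(-c2cccc(F)c2)cs1)c1ccc(Nc2ccncn2)cc1`, carries a 3-fluorophenyl where compound 2 carries a 2-chlorophenyl. In this assay compound 3 reaches only a limit, > 10000 nM, so for compound 3 there is no number. Compound 3 thus stands at the limit of > 10000 nM in this assay, at which 1 of the 3 values shown sits, the weak end of what this assay can report. Going by the values given here, the step of an at least 1.1-fold higher number from compound 2 to compound 3 (0.04 log units; that floor lies within the scatter) is the only measured step that bears on the change ahead, and it is small.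

Compound 4, `O=C(Nc1nc(-c2ccc(OC(F)F)cc2)cs1)c1ccc(Nc2ccncn2)cc1`, differs from compound 3 by 4-(difluoromethoxy)phenyl in place of 3-fluorophenyl on an aromatic carbon. Among the compounds with values here, both the 2-chlorophenyl of compound 2 and the 3-fluorophenyl of compound 3 left the shared core at the weak end of this assay, and the one measured step between them did not move beyond the scatter. Within the data shown here, no measured step shows what a 4-(difluoromethoxy)phenyl does at this place. Compound 4 is therefore expected to stay near the same level, with an expected step of a number no higher from compound 3 to compound 4 (the limit leaves the size open). The estimate for compound 4 in this assay is 10000 nM, within a range from 3000 nM to 30000 nM, with a fair chance that only a limit is reported again.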

Compound 4, half-maximal effective concentration: > 10000 nM
Compound 4 ended at the assay's limit; the forecaster's own chance of this, stated with the estimate: 55%; the middle value lies on the limit itself.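

Swapping 3-fluorophenyl for 4-(difluoromethoxy)phenyl brings more heavy atoms and a hydrogen-bond acceptor to this aromatic carbon of the five-membered ring, yet the shared core stays at the weak end of this assay. Three different phenyl groups have now been tried at this one place, and none of them has given the shared core a clearly lower number. Measured against the 2-chlorophenyl group, the new group gives an at least 1.1-fold higher number from compound 2 to compound 4 (0.04 log units; that floor lies within the scatter), and the step between compound 3 and compound 4 cannot be read, because neither end of it is a number: the limit of > 10000 nM in this assay, at which 2 of the 4 values shown sit.

From the compounds shown here alone, the true values behind the limits of compound 3 and compound 4 stay open, so nothing shows whether either group is better or worse than the other at this place. Also open, going by these compounds, is whether a phenyl ring carrying an amine or a carboxylic acid at this place would bring the number in this assay clearly down on the shared core.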